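The source may hold more compounds than are shown below. What is called first, only, known or untested is meant among the compounds shown, and "the series" means these compounds.

Compound 1 `Nc1cc(N)c2nc(-c3ccccc3)c(Oc3ccc(Cl)c(Cl)c3)nc2c1` is one of two compounds with a result in a functional assay on OVCAR-4 cells (Homo sapiens) for inhibition, read by sulforhodamine B assay, with a stated time of 48 h; a higher number here means a weaker inhibitor of growth, a lower number a stronger inhibitor of growth. In this assay compound 1 gives only a limit, < 100000 nM, so no exact number is known for it; that is the limit of < 100000 nM in this assay, at which 1 of the 2 values shown sits. Compound 2 `CCOC(=O)[C@H](CCC(=O)O)NC(=O)c1ccc(Sc2nc3cc(N)cc(N)c3nc2-c2ccccc2)cc1`, which carries a different and larger group on the shared core, gives in this assay a value of 53700 nM. Compound 3 `Nc1cc(N)c2nc(-c3ccccc3)c(Oc3ccc(F)cc3)nc2c1` has not yet been measured. It differs from compound 1 in one place, 4-fluorophenyl in place of 3,4-dichlorophenyl on an oxygen on an aromatic ring. For the measured compounds named here, no step between two measured compounds is available to show what size of change such a swap brings. Because compound 1 stands at the limit of < 100000 nM in this assay, at which 1 of the 2 values shown sits, the change is expected to move the value little, a step that the limit leaves unreadable from compound 1 to compound 3, in no direction beyond the usual scatter. Compound 3 is therefore estimated at 60000 nM in this assay, with a range from 20000 nM to 200000 nM.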

Compound 3, concentration for total growth inhibition: 35500 nM
The estimate for compound 3 lay 1.7-fold (0.23 log units) above the measured number; the measured number falls inside the stated range.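

The swap from compound 1 to compound 3 gives no readable step, because compound 1 has only a limit and no exact number: the limit of < 100000 nM in this assay, at which 1 of the 3 values shown sits. The compounds shown leave open whether 4-fluorophenyl in place of 3,4-dichlorophenyl changes the result in this assay at all, and by how much.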